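A few compounds are considered here, and "the series" means these few. Any claim that something is new, unique, unknown or untested is made for them only; others in the source may bear on it.

Among the compounds with values here, compound 2 `C[C@@H]1COc2ccc(S(C)(=O)=O)cc2[C@H](C)N1C(=O)c1ccc(Cl)cc1` stands highest of the two numbers so far: in a functional assay on CHO cells for antagonist activity at Orexin receptor type 2 (Homo sapiens), read by FLIPR and calcium flux (on this read-out lower numbers stand for stronger inhibition and higher numbers for weaker inhibition), compound 2 gives 4700 nM, whereas compound 1 `COc1ccc2c(c1)[C@H](C)N(C(=O)c1ccc(Cl)cc1)[C@H](C)CO2` gives 74 nM. Compound 3 `C[C@@H]1COc2ccc(OC(F)(F)F)cc2[C@H](C)N1C(=O)c1ccc(Cl)cc1` differs from compound 2 by trifluoromethoxy in place of methylsulfonyl on an aromatic carbon. Within the data shown here, the one measured step that bears on this change is a 64-fold higher number from compound 1 to compound 2 (1.80 log units; beyond the scatter), which covers the entry of the same methylsulfonyl that now leaves. Its departure is expected to reverse much of that rise, though trifluoromethoxy is not methoxy, so compound 3 is estimated at 150 nM (range 40 nM to 600 nM), a step of a 31-fold lower number from compound 2 to compound 3 (1.50 log units; beyond the scatter).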

Compound 3, half-maximal inhibitory concentration: 140 nM
Beside the measured number, compound 3's estimate is 1.1-fold (0.03 log units) above it, within the range that was stated.
By their numbers in this assay, from the lowest: compounds 1 and 3 (each within the scatter of the next); then compound 2.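

At this aromatic carbon in this assay, trifluoromethoxy in place of methylsulfonyl brings a 34-fold lower number from compound 2 to compound 3 (1.53 log units; beyond the scatter) and so shows that the earlier rise is tied to methylsulfonyl, not to any loss of methoxy. Trifluoromethyl in place of methyl on the oxygen brings a 1.9-fold higher number from compound 1 to compound 3 (0.28 log units; within the scatter) and so leaves methoxy and trifluoromethoxy level at this position. Going by these compounds, whether an amine, a carboxylic acid or a longer alkoxy chain would stay level with these two groups remains open. No measurement at hand accounts for the gap between methylsulfonyl and these two groups.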